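The compounds below may be only part of what the source reports. "The series", "measured", "known", "first", "only" and "open" are said of these compounds alone.

Three compounds share one core and differ in the group on a phenyl ring and in the amine-bearing side chain. Compound 3 `CC(=O)N1CCc2c(c(-c3ccc(OC(F)(F)F)cc3)nn2CC(O)CN2CCC(n3c(O)nc4ccccc43)CC2)C1` gives 130 nM in an assay on isolated protein for inhibition of cathepsin S (Homo sapiens) (on this read-out higher numbers stand for weaker inhibition and lower numbers for stronger inhibition), the second highest of the three numbers: compound 2 `CC(=O)N1CCc2c(c(-c3ccc(Cl)cc3)nn2CC(O)CN2CCC(n3c(O)nc4ccccc43)CC2)C1` gives 460 nM, and compound 1 `CC(=O)N1CCc2c(c(-c3ccc(Cl)cc3)nn2CC(O)CN2CCN(C(c3ccc(F)cc3)c3ccc(F)cc3)CC2)C1` gives 20 nM. Compound 4 `CC(=O)N1CCc2c(c(-c3ccc(I)cc3)nn2CC(O)CN2CCC(n3c(O)nc4ccccc43)CC2)C1` differs from compound 3 in one place: iodo in place of trifluoromethoxy on an aromatic carbon. For the measured compounds named here, only one measured step touches this position, the exchange of chloro for trifluoromethoxy, which gave a 3.5-fold lower number from compound 2 to compound 3 (0.55 log units; beyond the scatter). Going by the values given here, no measured step compares iodo with either group, so the direction is uncertain, and a step within or slightly beyond the scatter is expected, a 1.2-fold higher number from compound 3 to compound 4 (0.06 log units; within the scatter). Compound 4 is therefore estimated to give about 150 nM, within a range from 50 nM to 450 nM.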

Compound 4, half-maximal inhibitory concentration: 120 nM
Beside the measured number, compound 4's estimate is 1.3-fold (0.10 log units) above it, within the range that was stated.
By their numbers in this assay, from the lowest: compound 1; then compounds 4 and 3 (each within the scatter of the next); then compound 2.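

At this position, a single iodine atom and the five heavy atoms of trifluoromethoxy cannot be told apart (a 1.1-fold lower number from compound 3 to compound 4 (0.03 log units; within the scatter)). Iodo also reads clearly better than chloro (a 3.8-fold lower number from compound 2 to compound 4 (0.58 log units; beyond the scatter)), so chloro now falls short of two different groups rather than one. Nothing measured here explains this. The compounds shown leave open how an amine or a carboxylic acid would read on this aromatic carbon. They also leave open whether iodo would give a similar step on the side chain of compound 1.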